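The source may hold more compounds than are shown below. What is called first, only, known or untested is meant among the compounds shown, and "the series" means these compounds.

Measured so far, in an in vitro functional assay on HEK ts201 cells for antagonist activity at Neuronal acetylcholine receptor; alpha3/beta4 (Homo sapiens), read by fluorescence and calcium flux; on this read-out lower numbers stand for stronger inhibition and higher numbers for weaker inhibition:

Compound 1, `O=C(Nc1ccccn1)c1ccccc1-c1ccccc1`, gives 17500 nM.
Compound 2, `O=C(CCC1CCCNC1)c1ccccc1-c1ccccc1`, gives 6610 nM.
Compound 3, `O=C(OCC1CCCN(CCCc2ccccc2)C1)c1ccccc1N1C(=O)CC(Cc2ccc(Cl)cc2)C1=O`, gives 14500 nM.

Compound 3 sits second highest of these three numbers. Its nearest neighbour is compound 1, whose number is only slightly higher and within the usual scatter, so the two cannot be told apart. Compound 2 lies furthest away, with a lower number that sits beyond the scatter, so compound 2 inhibits more strongly than compound 3.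

Compound 4, `O=C(OCC1CCCN(CCCc2ccccc2)C1)c1ccccc1N1C(=O)CC(CCc2ccccc2)C1=O`, has not yet been measured. It differs from compound 3 in one place: benzyl in place of 4-chlorophenyl on a saturated chain carbon bound to a saturated ring carbon. Among the compounds with values here, no pair of measured compounds differs in just this way, so nothing measured here says what such a swap does. Because compound 3 itself gives 14500 nM, a weak number, the expectation is a small step, if any, in either direction, most likely not beyond the scatter. That expectation corresponds to a step of a 1.1-fold lower number from compound 3 to compound 4 (0.05 log units; within the scatter). Compound 4 is therefore estimated at 13000 nM, with a range from 5000 nM to 32000 nM.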

Compound 4, half-maximal inhibitory concentration: 33100 nM
Compound 4: the middle estimate sits 2.5-fold (0.41 log units) below what was measured; measured number outside the range, above it.
By their numbers in this assay, from the lowest: compound 2; then compounds 3, 1 and 4 (each within the scatter of the next, the first and the last beyond it).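

In this assay, exchanging 4-chlorobenzyl for phenethyl brings a 2.3-fold higher number from compound 3 to compound 4 (0.36 log units; beyond the scatter) and shows that this position responds to a change in its side group, even though both compounds inhibit only weakly. The group that leaves and the group that enters have the same count of heavy atoms, and each carries one six-membered aromatic ring of carbon only, so a swap that leaves these counts unchanged is still enough to move the number modestly beyond the scatter. Nothing measured here gives a reason for this step.

This single pair cannot separate the loss of the chlorine from the change in chain length, which a 4-chlorophenethyl group at the same place could help to tell apart. As far as these compounds go, what a chain ending in an amine or a carboxylic acid would do here also stays open.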